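The source may hold more compounds than are shown below. What is called first, only, known or untested is meant among the compounds shown, and "the series" means these compounds.

Compound 2 `Cc1ccc2c(NCc3ccc(NC(=O)C4CCN(Cc5ccccc5)CC4)cc3)nc(N(C)CCN(C)C)nc2c1` carries the shared core with a (2-(dimethylamino)ethyl)(methyl)amino group on an aromatic carbon. In a functional assay on SV5A8 cells (Homo sapiens) for cytotoxicity (a higher number here means a weaker inhibitor, a lower number a stronger inhibitor), compound 2 gives only a limit, > 8830 nM. Compound 1 `Cc1ccc2c(NCc3ccc(NC(=O)C4CCN(Cc5ccccc5)CC4)cc3)nc(N3CCN[C@@H](C)C3)nc2c1`, with 3-methylpiperazin-1-yl in that place, likewise gives only a limit in this assay, > 8860 nM. Within the data shown here, the one measured step, a step that the two limits leave unreadable from compound 1 to compound 2, cannot be read because the limit of > 8830 nM in this assay, at which 1 of the 2 values shown sits, and the limit of > 8860 nM in this assay, at which 1 of the 2 values shown sits, are both limits. Compound 3 `Cc1ccc2c(NCc3ccc(NC(=O)C4CCN(Cc5ccccc5)CC4)cc3)nc(N(C)CCCN(C)C)nc2c1` differs from compound 2 by (dimethylamino)methyl in place of dimethylamino on a saturated chain carbon, two bonds along the chain from a nitrogen on an aromatic ring. Among the measured compounds shown here, no measured step bears on a chain extension of this kind, and the two values shown offer nothing beyond the limits themselves. The expectation for compound 3 in this assay is that it, too, sits at or beyond the limit, with an expected step that the limit leaves unreadable from compound 2 to compound 3 that is unlikely to be readable. Compound 3 is estimated at 15000 nM, in the range 5000 nM to 50000 nM.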

Compound 3, half-maximal inhibitory concentration: > 8620 nM
Compound 3: only a limit was reported; the forecaster's own chance of this, stated with the estimate: 80%; the middle value lies beyond the limit too.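

In this assay compound 3 gives only a limit, > 8620 nM. Among these compounds, compound 1 and compound 2 also give only limits, so no step among the three can be read. The compounds shown leave open whether the group on the aromatic carbon alters the value in this assay at all.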